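A few compounds are considered here, and "the series" means these few. Any claim that something is new, unique, unknown or untested is made for them only; others in the source may bear on it.

Values in an ADME assay on MDBK cells (Bos taurus) for cytotoxicity (on this read-out higher numbers stand for lower toxicity in this test and lower numbers for higher toxicity in this test), follow
Compound 1 `Fc1cccc(F)c1Cn1c(-c2c(F)cccc2F)nc2cnccc21` gives > 100000 nM
Compound 2 `Fc1cccc(F)c1Cn1c(-c2c(F)cccc2F)nc2ccncc21` gives 99000 nM
Compound 3 `COc1ccc(Cn2ccc3nc(-c4ccccc4)nc-3c2)cc1` gives > 100000 nM

the limit of > 100000 nM in this assay, at which 2 of the 3 values shown sit, is where compound 3 stands, so its value is a limit of the assay and not a number. Compound 1 carries the same limit. Going by the values given here, compound 2 gives 99000 nM as the only exact number.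

Compound 4 `Brc1cccc(Cn2ccc3nc(-c4ccccc4)nc-3c2)c1` has 3-bromophenyl in place of 4-methoxyphenyl on a saturated chain carbon bound to an aromatic nitrogen, as 3-bromophenyl in place of 4-methoxyphenyl on a saturated chain carbon bound to an aromatic nitrogen counts. Among the compounds with values here, no measured pair shows this change, so the expectation in this assay rests on compound 2 at 99000 nM. The expectation also rests on compound 3, which gives > 100000 nM, a limit of the assay. The estimated step of a number no higher from compound 3 to compound 4 (the limit leaves the size open) is expected to stay within the scatter. Compound 4 is estimated at 100000 nM with 45000 nM to 200000 nM as the expected range.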

Compound 4, half-maximal cytotoxic concentration: 85000 nM
Estimate against measurement, compound 4: 1.2-fold (0.07 log units) above; the range from low to high includes it.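

In this assay, going by these compounds alone, 3-bromophenyl in place of 4-methoxyphenyl on a saturated chain carbon bound to an aromatic nitrogen gives the one step that can be read on this core: an at least 1.1-fold lower number from compound 3 to compound 4 (0.07 log units; that floor lies within the scatter). Compound 4 gives 85000 nM, an exact number. Compound 3 gives a limit and not a number, so the step has only a floor and its full size stays open: the limit of > 100000 nM in this assay, at which 2 of the 4 values shown sit.

From the compounds shown here alone, whether 4-bromophenyl would give a value like that of compound 4 stays open. So does the effect of an amine or a carboxylic acid on the phenyl ring.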